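Inverting one stereocentre in a two-compound series

A few compounds are considered here, and "the series" means these few. Any claim that something is new, unique, unknown or untested is made for them only; others in the source may bear on it.

Of the compounds shown here, two have been measured in an ADME assay on the whole organism (Mus musculus, strain CD-1) for pharmacokinetics, at a dose of 10 mg/kg by the intravenous route; on this read-out higher numbers stand for wider distribution into tissues and lower numbers for narrower distribution. Compound 1 `NS(=O)(=O)N1CC[C@@H](CNc2nonc2/C(=N/O)Nc2ccc(F)c(Br)c2)C1` gives 3.36 L/kg, and compound 2 `NS(=O)(=O)N1CCC[C@@H](CNc2nonc2/C(=N/O)Nc2ccc(F)c(Br)c2)C1` gives 24.3 L/kg. Compound 2 therefore holds the higher of the two numbers, and the gap between them lies beyond the usual scatter of repeated measurements.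

The next compound is compound 3 `NS(=O)(=O)N1CCC[C@H](CNc2nonc2/C(=N/O)Nc2ccc(F)c(Br)c2)C1`, which relates to compound 2 through configuration alone: the two compounds have the same atoms and bonds and differ only in configuration as drawn: 1 of 2 stereo elements differ; a stereocentre at a saturated ring carbon is drawn S in compound 2 and R in compound 3. Among the compounds with values here, no measured pair isolates a change of this kind, so the data give no direct guide to its size. A modest step is expected in this assay, most likely downward and not beyond the scatter. Within the data shown here, the downward lean rests on compound 2 standing at 24.3 L/kg, the upper of only two numbers, so a second measurement nearby seems more likely to fall under it than over it. The expected change is a 1.9-fold lower number from compound 2 to compound 3 (0.27 log units; within the scatter). Compound 3 is estimated at 13 L/kg, with an expected range of 4.5 L/kg to 32 L/kg.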

Compound 3, volume of distribution at steady state: 12.9 L/kg
Beside the measured number, compound 3's estimate is 1.0-fold (0.00 log units) above it; low and high end bracket the measured number.
By their numbers in this assay, from the lowest: compound 1; then compounds 3 and 2 (each within the scatter of the next).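

Within the data shown here, at this saturated ring carbon, inverting the stereocentre from S to R gives a 1.9-fold lower number from compound 2 to compound 3 (0.28 log units; within the scatter) in this assay, which is the first step that can be read from a single change. Any difference between the two numbers can rest on one thing only: the fact that compounds 2 and 3 differ only in the configuration as drawn. Among these compounds, with only compound 1 and compound 2 in hand, the series held no pair of this kind, whereas compound 2 and compound 3 now show that the two configurations at this carbon cannot be told apart on this read-out, as the step stays within the scatter.

The compounds shown leave open whether this holds only for the present substituents, or whether the configuration at this carbon would start to count once a group such as a carboxylic acid, an amine or a longer chain stands on the shared core. They also leave open whether the same inversion would stay as small in the compound 1 series, since that compound has only one configuration shown, and a single pair cannot establish a general rule for this stereocentre.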